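Adding a methoxy to compound 3

The source may hold more compounds than are shown below. What is called first, only, known or untested is meant among the compounds shown, and "the series" means these compounds.

Measured in an ADME assay on CCRF-CEM cells (Homo sapiens) for antiproliferative activity, with a stated time of 48 h; on this read-out lower numbers stand for stronger inhibition and higher numbers for weaker inhibition:
- compound 1 `C=C(Br)C(=O)Nc1ccc(C(=O)/C=C/c2ccccc2OC)cc1`: 580 nM
- compound 2 `C=C(Br)C(=O)Nc1ccc(C(=O)/C=C/c2ccc(OC)cc2OC)cc1`: 1100 nM
- compound 3 `COc1ccccc1/C=C/C(=O)c1ccc(N)cc1`: 6300 nM

Of the three, compound 3 shows the highest number, 6300 nM, and so the weakest inhibition on these values. Compound 4 `COc1ccc(/C=C/C(=O)c2ccc(N)cc2)c(OC)c1` differs from it in one place: methoxy in place of hydrogen on an aromatic carbon. This is methoxy in place of hydrogen on an aromatic carbon, meta to a methoxy group and para to a large group.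

The closest evidence is a 1.9-fold higher number from compound 1 to compound 2 (0.28 log units; within the scatter), which is the same methoxy in place of hydrogen on an aromatic carbon, and that step lies within the scatter. Among the measured compounds shown here, it was seen only with (1-bromoethenyl)carbonyl on the nitrogen, and no measured pair shows the same change with hydrogen there. The other measured step, an 11-fold higher number from compound 1 to compound 3 (1.04 log units; beyond the scatter), is large, but it concerns the group on the nitrogen, which stays the same here. No change beyond the scatter is therefore expected in this assay, only a slight lean towards a higher number. The expected step is a 1.3-fold higher number from compound 3 to compound 4 (0.10 log units; within the scatter). For compound 4 the estimated value is 8000 nM, with an expected range from 3500 nM to 18000 nM.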

Compound 4, half-maximal inhibitory concentration: 18000 nM
Estimate against measurement, compound 4: 2.3-fold (0.35 log units) below; low and high end bracket the measured number.
By their numbers in this assay, from the lowest: compounds 1 and 2 (each within the scatter of the next); then compound 3; then compound 4.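

In this assay, methoxy in place of hydrogen on an aromatic carbon, meta to a methoxy group and para to a large group, now gives a modest step beyond the scatter with hydrogen on the nitrogen, a 2.9-fold higher number from compound 3 to compound 4 (0.46 log units; beyond the scatter), whereas with (1-bromoethenyl)carbonyl on the nitrogen the same change stayed within the scatter. That contrast should not be read as a real dependence on the group on the nitrogen, as the two steps themselves lie close together: the same change on two cores in this assay, a 1.9-fold higher number (0.28 log units; within the scatter) from compound 1 to compound 2 and a 2.9-fold higher number (0.46 log units; beyond the scatter) from compound 3 to compound 4, 1.5-fold (0.18 log units) apart, within the scatter of two such steps The second new step, a 16-fold higher number from compound 2 to compound 4 (1.21 log units; beyond the scatter), shows that replacing (1-bromoethenyl)carbonyl on the nitrogen with hydrogen gives a large step with this methoxy present as well as without it, and the size of that step holds across the two cores: the same change on two cores in this assay, an 11-fold higher number (1.04 log units; beyond the scatter) from compound 1 to compound 3 and a 16-fold higher number (1.21 log units; beyond the scatter) from compound 2 to compound 4, 1.5-fold (0.18 log units) apart, within the scatter of two such steps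

The compounds shown leave open whether a hydroxy, an ethoxy or a fluorine at this place on the ring would give a step like that of methoxy. They also leave open whether a propenoyl or an acetyl group on the nitrogen would retain the lower numbers seen with (1-bromoethenyl)carbonyl.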